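The compounds below may be only part of what the source reports. "The series", "measured", "known", "first", "only" and "open" are said of these compounds alone.

Compound 1, `C=C(Cc1ccccc1)C(=O)Nc1ccccc1`, and compound 2, `C/C=C/C(=O)Nc1ccccc1`, have both been examined in an ADME assay for pharmacokinetics, read by LC-MS, in phosphate buffer, with a stated time of 120 min, at pH 7.4, tested at 1 uM, in the presence of a further agent that is not named here; on this read-out higher numbers stand for a longer-lived compound and lower numbers for a shorter-lived compound. In this assay compound 1 gives > 8.53 h, which is a limit of the assay rather than a number. Compound 2 gives > 8.53 h, also a limit. On the numbers shown, compound 1 therefore stands at the limit of > 8.53 h in this assay, at which 2 of the 2 values shown sit, so its true half-life is known only to be long. The next compound, compound 3, `C=C(CCO)C(=O)Nc1ccccc1`, has not yet been tested. It differs from compound 1 in one place: hydroxymethyl in place of phenyl on a saturated chain carbon bound to a double-bonded chain carbon. For the measured compounds named here, no measured pair shows how such a change alters the half-life, so the estimated step is a number no higher from compound 1 to compound 3 (the limit leaves the size open), nothing beyond the usual scatter and with no clear direction. Compound 3 is accordingly expected to give about 8.5 h in this assay, with an estimated range from 3 h to 20 h.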

Compound 3, half-life: > 8.53 h
Compound 3 was reported as a limit; the forecaster's own chance of this, stated with the estimate: 60%; middle value at least 1.0-fold (0.00 log units) from the limit.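

Compound 1 and compound 3 both sit at a limit of this assay, not at a number, so no step between them can be read: the limit of > 8.53 h in this assay, at which 3 of the 3 values shown sit.

How long the half-life of each compound shown really is stays open, and so does whether hydroxymethyl in place of phenyl alters it at all.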